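Glycerol phosphodiester of the shared core: an expectation

A few compounds are considered here, and "the series" means these few. Any claim that something is new, unique, unknown or untested is made for them only; others in the source may bear on it.

Three cytidine-derived phosphodiesters have been measured so far in a functional assay on B16 cells (Mus musculus) for inhibition; a lower number here means a stronger inhibitor, a higher number a weaker inhibitor. Compound 1 `CCOP(=O)(O)OC[C@H]1O[C@@H](n2ccc(N)nc2=O)[C@@H](O)[C@@H]1O` gives 70 uM in this assay. Compound 2 `CCCCOP(=O)(O)OC[C@H]1O[C@@H](n2ccc(N)nc2=O)[C@@H](O)[C@@H]1O` gives 130 uM in this assay, and compound 3 `Nc1ccn([C@@H]2O[C@H](COP(=O)(O)OCc3cccc(OCC(O)CO)c3)[C@@H](O)[C@@H]2O)c(=O)n1` gives 25 uM in this assay. Compound 2 thus holds the highest number of the three; it sits within the scatter of compound 1 and beyond it only against compound 3.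

The unmeasured compound 4 `Nc1ccn([C@@H]2O[C@H](COP(=O)(O)OCC(O)CO)[C@@H](O)[C@@H]2O)c(=O)n1` differs from compound 2 in one place: 1,2-dihydroxyethyl in place of propyl on a saturated chain carbon bound to an oxygen on an unsaturated carbon.

Among the compounds with values here, only one measured step bears on this change, and only loosely. The step of a 1.9-fold higher number from compound 1 to compound 2 (0.27 log units; within the scatter) lengthened the same chain without any hydroxyl and stayed within the scatter. Compound 3 carries a 2,3-dihydroxypropoxy group as well, but on a benzyl ester, so its value against compound 2 cannot be read as a single step. The two hydroxyl groups entering in compound 4 have no measured parallel on this chain.

Compound 4 is therefore expected to land near compound 2, with a modest shift toward a lower number, giving an estimated 1.9-fold lower number from compound 2 to compound 4 (0.27 log units; within the scatter). The expected value for compound 4 is 70 uM, within a range from 25 uM to 200 uM.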

Compound 4, concentration for 50% inhibition: 26 uM
Estimate against measurement, compound 4: 2.7-fold (0.43 log units) above; the range from low to high includes it.
By their numbers in this assay, from the lowest: compounds 3 and 4 (each within the scatter of the next); then compounds 1 and 2 (each within the scatter of the next).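

In this assay the exchange of propyl for 1,2-dihydroxyethyl on the saturated chain carbon bound to an oxygen on an unsaturated carbon moves the number clearly (a 5.0-fold lower number from compound 2 to compound 4 (0.70 log units; beyond the scatter)), whereas the earlier change on this chain, which added only carbon, stayed within the scatter (a 1.9-fold higher number from compound 1 to compound 2 (0.27 log units; within the scatter)). The lower number also holds against the shorter chain, with 1,2-dihydroxyethyl in place of methyl (a 2.7-fold lower number from compound 1 to compound 4 (0.43 log units; beyond the scatter)), so at this position the dihydroxylated chain stands apart from both plain alkyl chains shown, and the result does not rest on butyl alone as the point of comparison. Nothing among the data shown accounts for this shift.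

The compounds shown leave open whether both hydroxyl groups are needed, since a chain with a single hydroxyl, such as 2-hydroxyethyl or 3-hydroxypropyl, would separate the contribution of each from that of the pair. They also leave open whether the lower number is specific to hydroxyl groups or would also appear with an amine or a carboxylic acid at the end of the chain.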